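The source may hold more compounds than are shown below. What is called first, only, known or untested is meant among the compounds shown, and "the series" means these compounds.

Series notes. The shared core carries a chain on the aromatic nitrogen, and three members have been measured in an assay on isolated protein for inhibition of Gonadotropin-releasing hormone receptor (Rattus norvegicus); a lower number here means a stronger inhibitor, a higher number a weaker inhibitor. Compound 1 `CCn1c(SCc2cc([N+](=O)[O-])ccc2OC)nc2cc(NC(=O)NC(C)(C)C)ccc21` gives 170 nM in this assay. Compound 2 `CCCn1c(SCc2cc([N+](=O)[O-])ccc2OC)nc2cc(NC(=O)NC(C)(C)C)ccc21` gives 120 nM in this assay. Compound 3 `CCCCCn1c(SCc2cc([N+](=O)[O-])ccc2OC)nc2cc(NC(=O)NC(C)(C)C)ccc21` gives 880 nM in this assay, the highest of the three numbers. The steps between them are a 1.4-fold lower number from compound 1 to compound 2 (0.15 log units; within the scatter), a 5.2-fold higher number from compound 1 to compound 3 (0.71 log units; beyond the scatter) and a 7.3-fold higher number from compound 2 to compound 3 (0.87 log units; beyond the scatter): ethyl and propyl lie within the scatter of each other, while the longer chain of compound 3 costs clearly. Compound 4 `COCCn1c(SCc2cc([N+](=O)[O-])ccc2OC)nc2cc(NC(=O)NC(C)(C)C)ccc21` is not yet measured; it differs from compound 3 by methoxy in place of propyl on a saturated chain carbon, two bonds along the chain from an aromatic nitrogen. Within the data shown here, the change trims the chain back toward the size found in compound 2 and brings in an acceptor, for which no measured step exists in this set. Because a 7.3-fold higher number from compound 2 to compound 3 (0.87 log units; beyond the scatter) shows the cost of the longer chain, compound 4 is expected to recover part of it, and the expected step is a 3.5-fold lower number from compound 3 to compound 4 (0.55 log units; beyond the scatter). For compound 4 the estimate in this assay is 250 nM, with a range from 90 nM to 700 nM.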

Compound 4, half-maximal inhibitory concentration: 280 nM
The estimate for compound 4 lay 1.1-fold (0.05 log units) below the measured number, and the stated range covers the measured number.
By their numbers in this assay, from the lowest: compounds 2, 1 and 4 (each within the scatter of the next, the first and the last beyond it); then compound 3.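

Methoxy in place of propyl at this place on the chain gives a 3.1-fold lower number from compound 3 to compound 4 (0.50 log units; beyond the scatter) in this assay, so the cost carried by the pentyl chain of compound 3 can be partly reversed by an ether-bearing chain, a kind of change the earlier alkyl chains did not cover. The reversal is incomplete against the propyl chain, with a 2.3-fold higher number from compound 2 to compound 4 (0.37 log units; beyond the scatter), whereas a 1.6-fold higher number from compound 1 to compound 4 (0.22 log units; within the scatter) leaves the 2-methoxyethyl chain within the scatter of the ethyl chain. No measurement bears on why the number moves in this way.

Still open, going by these compounds, is whether the lower number for compound 4 follows the oxygen or the shorter carbon chain. A butyl chain on the aromatic nitrogen, and 2-hydroxyethyl or 2-aminoethyl chains there, would bear on that question.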